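Cytotoxicity notes on the bis-benzylidene piperidinone triazole series

This account rests on a few compounds, and the source may have more. Where it says the series, first, only, none or still open, it means among the compounds named here.

Measured so far:
- compound 1 `O=C1/C(=C/c2ccccc2F)CN(Cc2cn(Cc3ccc(F)cc3)nn2)C/C1=C\c1ccccc1F`: 46000 nM
- compound 2 `Cc1ccc(/C=C2\CN(C(=S)SCc3cn(Cc4ccccc4Cl)nn3)C/C(=C\c3ccc(C)cc3)C2=O)cc1`: "not determined" (no result reported)

For the measured compounds named here, in an ADME assay on HEK293 cells (Homo sapiens) for cytotoxicity, read by MTT assay, with a stated time of 24 h (a higher number here means a weaker inhibitor, a lower number a stronger inhibitor), compound 1 gives 46000 nM, the only number available, with compound 2 carrying no result. The new member, compound 3 `O=C1/C(=C/c2ccccc2F)CN(Cc2cn(Cc3ccccc3F)nn2)C/C1=C\c1ccccc1F`, differs from compound 1 only in one group: 2-fluorophenyl in place of 4-fluorophenyl on a saturated chain carbon bound to an aromatic nitrogen. Going by the values given here, no step between two measured compounds exists to calibrate such a change, and the shared core is untouched. The cytotoxic readout is therefore expected to stay put, with the step from compound 1 to compound 3 no larger than the usual scatter, no change at the digits printed from compound 1 to compound 3 (within the scatter). Compound 3 is estimated at 46000 nM, within 20000 nM to 100000 nM.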

Compound 3, half-maximal inhibitory concentration: 41200 nM
The estimate for compound 3 lay 1.1-fold (0.05 log units) above the measured number, and the stated range covers the measured number.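

In this assay, for the compounds shown here, 2-fluorophenyl in place of 4-fluorophenyl on a saturated chain carbon bound to an aromatic nitrogen gives a 1.1-fold lower number from compound 1 to compound 3 (0.05 log units; within the scatter) and provides the first readable step. At this position, the two fluorophenyl groups therefore cannot be told apart in this read-out, something a single value could not show. Nothing available explains this result.

Still open, as far as these compounds go, is whether an amine or a carboxylic acid in place of the fluorine would move the number. The same question applies to a longer chain at this position.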